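Methyl for fluoro on a quinoline sulfone core at glutamate receptor 5

This account rests on a few compounds, and the source may have more. Where it says the series, first, only, none or still open, it means among the compounds named here.

Measured compounds:
compound 1 `Cc1ccc(S(=O)(=O)c2cnc3ccc(F)cc3c2N2CCC(C)CC2)cc1C` gives 92%
compound 2 `Cc1ccc2ncc(S(=O)(=O)c3ccc(C)c(C)c3)c(N3CCC(C)CC3)c2c1` gives 90%
compound 3 `CC1CCN(c2c(S(=O)(=O)c3ccccc3)cnc3ccc(F)cc23)CC1` gives 40%

The three compounds were tested in an assay on isolated protein for displacement of a labelled ligand from metabotropic glutamate receptor 5 (Homo sapiens), with a stated time of 60 min, tested at 1 uM; a lower number here means less inhibition, a higher number more inhibition at the concentration tested (going by the name of the read-out). Compound 1 and compound 2 differ by methyl in place of fluoro on an aromatic carbon and the step between them is a number 2 percentage points lower from compound 1 to compound 2 (within the scatter). Compound 3 carries a different sulfonyl substituent, and the difference between its core and that of compound 1 is phenyl in place of 3,4-dimethylphenyl on a sulfonyl sulfur; the step that goes with this change is a number 52 percentage points lower from compound 1 to compound 3 (beyond the scatter). Compound 3 thus stands lowest of the three in this assay.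

Compound 4 `Cc1ccc2ncc(S(=O)(=O)c3ccccc3)c(N3CCC(C)CC3)c2c1` has not been measured. For the measured compounds named here, it differs from compound 3 by methyl in place of fluoro on an aromatic carbon, which is the same change, at the same place on the ring, as the one made from compound 1 to compound 2. Because that earlier step was a number 2 percentage points lower from compound 1 to compound 2 (within the scatter), the step from compound 3 to compound 4 is expected to be small as well, about no change at the digits printed from compound 3 to compound 4 (within the scatter). On this basis compound 4 is estimated to give 40% in this assay, with a likely range from 25% to 55%.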

Compound 4, a percentage reported as inhibition, at one concentration (the size of the read-out at that concentration, not a potency): 67%
For compound 4 the middle estimate is 27 percentage points below the measured one, and the stated range ends below it.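

In this assay, methyl in place of fluoro on an aromatic carbon did not carry over unchanged from the core with the 3,4-dimethylphenyl group on the sulfonyl sulfur to the core with phenyl there, giving a number 27 percentage points higher from compound 3 to compound 4 (beyond the scatter): the same change on two cores in this assay, a number 2 percentage points lower (within the scatter) from compound 1 to compound 2 and a number 27 percentage points higher (beyond the scatter) from compound 3 to compound 4, 29 percentage points apart, beyond the scatter of two such steps

Read the other way, phenyl in place of 3,4-dimethylphenyl on a sulfonyl sulfur gave a lower number on both cores, but the size of that step depended on the core, with a number 23 percentage points lower from compound 2 to compound 4 (beyond the scatter): the same change on two cores in this assay, a number 52 percentage points lower (beyond the scatter) from compound 1 to compound 3 and a number 23 percentage points lower (beyond the scatter) from compound 2 to compound 4, 29 percentage points apart, beyond the scatter of two such steps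

This shows that in these four compounds the two changes do not act independently of one another; it does not show why, and a single pair of cores cannot tell how the methyl for fluoro step would behave with any other group on the sulfonyl sulfur.

The compounds shown leave open whether the same gap between steps would appear with chloro, methoxy or nitrile on that aromatic carbon. They also leave open whether it would hold with an ethyl or a cyclopropyl group in place of the methyl.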